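A few compounds are considered here, and "the series" means these few. Any claim that something is new, unique, unknown or untested is made for them only; others in the source may bear on it.

In a functional assay on HCT-116 cells (Homo sapiens) for inhibition, read by CCK-8 assay, with a stated time of 72 h, tested at 8 uM (on this read-out lower numbers stand for less inhibition of growth and higher numbers for more inhibition of growth at the one concentration tested), compound 1 `CCc1ccc(SCc2ccc(C(=O)Nc3ccccc3N)cc2)cc1` reaches 79.1%. Within the data shown here, that is the higher of the two numbers measured so far: compound 2 `Cc1ccc(SCc2ccc(/C=C/C(=O)Nc3ccccc3N)cc2)cc1` gives only 4.93%, a gap well beyond the usual scatter. Compound 3 `Nc1ccccc1NC(=O)c1ccc(CSc2ccc(Br)cc2)cc1` has not yet been measured. It keeps everything in compound 1 except one group: bromo in place of ethyl on an aromatic carbon. Among the measured compounds shown here, no measured pair of compounds shows what such a swap does, so the expectation leans on compound 1 at 79.1% alone. A small drop, or no change beyond the scatter, seems most likely in this assay. The estimated step is a number 5.1 percentage points lower from compound 1 to compound 3 (within the scatter). For compound 3 the expected growth inhibition is 74%, with an estimated range of 55% to 90%.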

Compound 3, percent growth inhibition at one concentration: 67.7%
For compound 3 the middle estimate is 6.3 percentage points above the measured one, and the stated range covers the measured number.
By their numbers in this assay, from the lowest: compound 2; then compound 3; then compound 1.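

In this assay, among these compounds, changing the 4-ethylphenyl end to 4-bromophenyl gives a number 11.4 percentage points lower from compound 1 to compound 3 (beyond the scatter), the first step here that can be read at a single place in the structure. It shows that the number responds to the group sitting on this aromatic carbon, yet compound 3 still gives 67.7%, so growth inhibition stays well away from the low number of compound 2, which differs from compound 1 in more than one place. No measurement here accounts for the size of this step.

On these data alone, with only ethyl and bromo compared at this place, it remains open whether a chloro, a methoxy, an amine or a carboxylic acid would land nearer compound 1 or fall much lower. A longer chain, such as propyl or butyl, is equally untested by the compounds shown.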